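Aryl swap at the shared core: pyridyl for cyanophenyl

The compounds below may be only part of what the source reports. "The series", "measured", "known", "first", "only" and "open" are said of these compounds alone.

Within the data shown here, compound 2 `N#Cc1ccc(-c2cnc3[nH]cc(-c4nnc(-c5ccc(Cl)cc5)o4)c(=O)c3c2)cc1` stands at the top of the two numbers measured so far: in a functional assay on HCT-116 cells (Homo sapiens) for positive allosteric modulation, read by MTT assay, with stated times of 24 h and 48 h, tested at 2.5 uM (a higher number here means more inhibition of growth at the concentration tested, a lower number less inhibition of growth), compound 2 gives 35.4%. Among the measured compounds shown here, its only neighbour is compound 1 `CS(=O)(=O)c1ccc(-c2cnc3[nH]cc(-c4nnc(-c5ccc(Cl)cc5)o4)c(=O)c3c2)cc1`, which in this assay gives 24.9%; the single measured step, a number 10.5 percentage points higher from compound 1 to compound 2 (beyond the scatter), concerns the same position but a different pair of groups. Compound 3 `O=c1c(-c2nnc(-c3ccc(Cl)cc3)o2)c[nH]c2ncc(-c3cccnc3)cc12` differs from compound 2 by pyridin-3-yl in place of 4-cyanophenyl on an aromatic carbon. For the measured compounds named here, no measured step replaces the whole 4-cyanophenyl group, so the one step on record gives no direct guidance on direction; it shows only that a change of the group at this position can move this assay beyond the scatter. The expected step from compound 2 to compound 3 is therefore small, a number 5.4 percentage points lower from compound 2 to compound 3 (within the scatter), with no firm direction. Compound 3 is estimated at 30%, with a range from 18% to 42%.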

Compound 3, percent growth inhibition at one concentration: 20.1%
Beside the measured number, compound 3's estimate is 9.9 percentage points above it; the range from low to high includes it.
By their numbers in this assay, from the lowest: compounds 3 and 1 (each within the scatter of the next); then compound 2.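

In this assay, compound 2 now stands apart from a second group at this position, with a number 15.3 percentage points lower from compound 2 to compound 3 (beyond the scatter), so the earlier separation from compound 1 is not a single isolated step. Pyridin-3-yl and 4-(methylsulfonyl)phenyl are not told apart, with a number 4.8 percentage points lower from compound 1 to compound 3 (within the scatter), leaving compound 2 as the only one of the three separated from both others. The change from compound 2 to compound 3 replaces the carbon-only ring and removes the nitrile in one step, and nothing at hand accounts for the difference.

Open, as far as these compounds go, is whether the nitrile or the carbon-only ring carries the difference: plain phenyl and a pyridin-3-yl bearing a nitrile would separate the two. Also open, from the compounds shown here alone, is how a 4-aminophenyl or 4-carboxyphenyl group would compare with 4-cyanophenyl at this position.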